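The compounds below may be only part of what the source reports. "The series", "measured", "known", "first", "only" and "open" are said of these compounds alone.

Measured so far in a functional assay on the whole organism with Mus musculus as the target, with a stated time of 15 min; a lower number here means that less compound is needed, a higher number that more compound is needed for the effect:

Compound 1 `Cc1sc2ccccc2c1C1NC(N)=NC=C1Cl` — 30 mg/kg
Compound 2 `Cc1sc2cccc(F)c2c1C1C=CN=CN1` — 3 mg/kg
Compound 3 `Cc1c(F)sc(C2C=CN=CN2)c1C` — 10 mg/kg

Compound 2 needs the smallest dose of the three. Compound 3 sits higher, beyond the usual scatter, and compound 1 higher still, also beyond the scatter. None of these three compounds differs from another in only one place, so no single structural change can be read off between measured compounds.

Compound 4 `Cc1sc2ccccc2c1C1C=CN=CN1` has not yet been measured. It differs from compound 2 in one place: hydrogen in place of fluoro on an aromatic carbon. The fluoro leaves from an aromatic carbon of the six-membered aromatic ring of carbon only in the fused two-ring system, and hydrogen takes its place; nothing else in the structure changes.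

For the measured compounds named here, with no measured pair showing this change, the expected step can only be a cautious one. The expected step in this assay is a 1.7-fold higher number from compound 2 to compound 4 (0.22 log units; within the scatter), a modest rise in dose, close to the scatter. Compound 4 is therefore expected to give about 5 mg/kg, within a range from 2 mg/kg to 15 mg/kg.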

Compound 4, minimum effective dose: 3 mg/kg
For compound 4 the middle estimate is 1.7-fold (0.22 log units) above the measured one, within the range that was stated.
By their numbers in this assay, from the lowest: compounds 2 and 4 (each within the scatter of the next); then compound 3; then compound 1.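

In this assay, putting hydrogen in place of fluoro on this aromatic carbon gives no change at the digits printed from compound 2 to compound 4 (within the scatter). For the compounds shown here, this is the first pair of measured compounds that differ in one place, so the fluoro can now be judged alone: on this carbon of the shared core, it is not needed to reach the dose seen for compound 2. Nothing measured here offers an explanation for this result.

The compounds shown leave open whether another group on the same carbon, such as methoxy, an amine or a carboxylic acid, would also leave the dose unchanged or would shift it. They also leave open whether the same exchange of fluoro for hydrogen would be as quiet on another carbon of this six-membered ring.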